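Working notes: adding a methoxy to compound 2

The source may report more compounds than this note shows. Statements on the series, on what has been measured and on what is new or still open speak of the compounds shown alone.

Values measured in a functional assay on HL-60 cells (Homo sapiens) for inhibition, read by MTT assay, with a stated time of 72 h (a lower number here means a stronger inhibitor, a higher number a weaker inhibitor), are as follows.
- compound 1 `COc1ccc(-c2nc(C)oc2C(=O)N2CCN(c3cccc(Cl)c3)CC2)cc1` gives "not active" (no number reported)
- compound 2 `CCCc1nc(-c2ccc(OC)cc2)c(C(=O)N2CCN(c3cccc(Cl)c3)CC2)o1` gives "not active" (no number reported)
- compound 3 `CCc1nc(-c2ccc(OC)cc2)c(C(=O)N2CCN(c3cccc(Cl)c3)CC2)o1` gives > 1000 nM

Compound 2 has no single number in this assay and is reported as "not active" (no number reported) (the same entry as compound 1 "not active" (no number reported)). Compound 3 gives > 1000 nM and this is a limit, not a number. None of the three compounds has yet given a number, and only one figure frames the series (the limit of > 1000 nM in this assay, at which 1 of the 3 values shown sits).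

Compound 4 `CCCc1nc(-c2ccc(OC)c(OC)c2)c(C(=O)N2CCN(c3cccc(Cl)c3)CC2)o1` carries a 3,4-dimethoxyphenyl group where compound 2 carries 4-methoxyphenyl. The change methoxy in place of hydrogen on an aromatic carbon places methoxy in place of hydrogen on an aromatic carbon, ortho to a methoxy group and meta to a large group.

Going by the values given here, no measured pair shows this change, so its size in this assay rests on expectation alone. A modest step toward stronger inhibition is the most that is expected, and an entry again without a number is the likeliest outcome. For compound 4 the expected value is 1500 nM with an estimated range from 300 nM to 8000 nM in this reading.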

Compound 4, half-maximal inhibitory concentration: "not active" (no number reported)
For compound 4 the study gives words and no number; the estimate stays without a comparison.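

No step can be read from compound 2 to compound 4: neither entry carries a number. What methoxy in place of hydrogen does to inhibition in this assay stays open, and the only figure framing the series is a limit: the limit of > 1000 nM in this assay, at which 1 of the 4 values shown sits.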